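The source may hold more compounds than are shown below. What is called first, only, known or untested is meant among the compounds shown, and "the series" means these compounds.

Measured so far in a functional assay on THP-1 cells (Homo sapiens) for inhibition, read by sulforhodamine B assay, with a stated time of 48 h; on this read-out higher numbers stand for weaker inhibition and lower numbers for stronger inhibition:
- compound 1 `COC(=O)[C@H]1C[C@@H](c2coc3ccccc3c2=O)N(c2ccccc2)O1`: > 60000 nM, a limit
- compound 2 `O=c1c([C@@H]2C[C@H](c3ccccc3)ON2c2ccccc2)coc2ccccc12`: > 60000 nM, a limit
- compound 3 `COC(=O)[C@H]1C[C@@H](c2coc3ccc(Cl)cc3c2=O)N(c2ccccc2)O1`: > 60000 nM, a limit

Compound 3 has no number of its own, since its > 60000 nM is a limit. The two other compounds give limits as well, so all three rest on (the limit of > 60000 nM in this assay, at which 3 of the 3 values shown sit).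

Compound 4 `N#C[C@H]1C[C@@H](c2coc3ccc(Cl)cc3c2=O)N(c2ccccc2)O1` keeps the core of compound 3 and differs in one place, with cyano in place of methoxycarbonyl on a saturated ring carbon.

Going by the values given here, two measured steps bear on this change. The closer one alters the same group, with phenyl in place of methoxycarbonyl on a saturated ring carbon, and it is a step that the two limits leave unreadable from compound 1 to compound 2. The other, chloro in place of hydrogen on an aromatic carbon, is a step that the two limits leave unreadable from compound 1 to compound 3. Neither gives a size, so the series offers no measure of how far this assay can move with such a change. No step beyond the usual scatter is therefore expected, and another limit is the likeliest result, though a number near the top of the range remains possible. The expected change is estimated as an at least 1.2-fold lower number from compound 3 to compound 4 (0.07 log units; that floor lies within the scatter). For compound 4 the estimate is 50000 nM, with an expected range from 15000 nM to 90000 nM.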

Compound 4, half-maximal inhibitory concentration: 35000 nM
Compound 4: the middle estimate sits 1.4-fold (0.15 log units) above what was measured; the range from low to high includes it.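

In this assay, going by these compounds alone, compound 4 gives 35000 nM, so cyano in place of methoxycarbonyl on this saturated ring carbon, next to the ring oxygen, yields the first readable number. Within the data shown here, the change reads as an at least 1.7-fold lower number from compound 3 to compound 4 (0.23 log units; that floor lies within the scatter); this is a floor rather than a measured size, and the earlier steps cannot be read. Compound 4 is thus the only compound shown with a number of its own, and the others remain at a single limit: the limit of > 60000 nM in this assay, at which 3 of the 4 values shown sit.

The compounds shown leave open whether cyano would also give a number on the core of compound 1, which carries hydrogen in place of chloro, and so whether this result depends on the chloro group. They also leave open how a carboxylic acid, a primary amide or a hydroxymethyl group on the same saturated ring carbon would read in this assay, and whether any such group would move the number further than cyano does.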